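Replacing a thioester side chain with vinyl

A few compounds are considered here, and "the series" means these few. Any claim that something is new, unique, unknown or untested is made for them only; others in the source may bear on it.

In a functional assay on BXPC-3 cells (Homo sapiens) for antiproliferative activity, read by sulforhodamine B assay, with a stated time of 72 h (on this read-out lower numbers stand for stronger inhibition and higher numbers for weaker inhibition), the measured compounds read as follows
- compound 1 `C=CCOC(=O)C1=C2C(=NC1=O)c1cccc3c(SCCC)ccc2c13` gives 12900 nM
- compound 2 `C=CCSc1ccc2c3c(cccc13)C1=NC(=O)C(C(=O)OCC(=O)SCCC)=C12` gives 13700 nM

Compound 2 at 13700 nM stands within the usual scatter of compound 1 at 12900 nM and the two cannot be ranked. Compound 3 `C=CCOC(=O)C1=C2C(=NC1=O)c1cccc3c(SCC=C)ccc2c13` has not yet been measured. Its difference from compound 2 is vinyl in place of (propylsulfanyl)carbonyl on a saturated chain carbon bound to an oxygen next to a carbonyl group and amounts to vinyl in place of (propylsulfanyl)carbonyl on a saturated chain carbon bound to an oxygen next to a carbonyl group. Going by the values given here, no measured step shows what such a change does, so the expectation rests only on how closely the two known values lie. An estimated 1.2-fold lower number from compound 2 to compound 3 (0.10 log units; within the scatter) would stay within the scatter of this assay and no step beyond it is expected. Compound 3 is expected at 11000 nM with an estimated range from 4500 nM to 27000 nM for this measurement.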

Compound 3, half-maximal inhibitory concentration: 2500 nM
Compound 3: the middle estimate sits 4.4-fold (0.64 log units) above what was measured, outside the stated range (below it).
By their numbers in this assay, from the lowest: compound 3; then compounds 1 and 2 (each within the scatter of the next).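

In this assay, going by these compounds alone, vinyl in place of (propylsulfanyl)carbonyl on a saturated chain carbon bound to an oxygen next to a carbonyl group gives a 5.5-fold lower number from compound 2 to compound 3 (0.74 log units; beyond the scatter), so this position responds to the change although no earlier step had tested it. Vinyl in place of ethyl on a saturated chain carbon bound to a sulfur gives a 5.2-fold lower number from compound 1 to compound 3 (0.71 log units; beyond the scatter), so the chain on sulfur responds as well, and compound 3, which carries the vinyl at both places, has the lowest number of the three. Nothing measured on these compounds accounts for either step.

The compounds shown leave open whether the vinyl end itself matters or whether a plain propyl on the ester oxygen chain would serve equally well. They also leave open how a carboxylic acid or an amine at the end of either chain would read.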